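Bromine position: the step from compound 2 to compound 4

The compounds below may be only part of what the source reports. "The series", "measured", "known", "first", "only" and "open" are said of these compounds alone.

In a functional assay on the whole organism (strain Kunming) with Mus musculus as the target, in the formalin test, with a stated time of 0.5 h (a higher number here means that more compound is needed for the effect, a lower number that less compound is needed), compound 2 (`COc1cc(OC)c(OC)cc1/C=C/COC(=O)/C=C/c1ccc(Br)cc1`) gives 243 umol/kg. Compound 3 (`COc1cc(OC)c(OC)cc1/C=C/COC(=O)/C=C/c1cc(OC)c(OC)c(OC)c1`) gives 192 umol/kg, which lies within the scatter of compound 2. Compound 1 (`COc1cc(OC)c(OC)cc1/C=C/COC(=O)/C=C/c1cc(OC)c(OC)c(OC)c1OC`) gives 89 umol/kg, a lower number than compound 2, with the gap beyond the scatter.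

Compound 4 (`COc1cc(OC)c(OC)cc1/C=C/COC(=O)/C=C/c1cccc(Br)c1`) has the same atoms as compound 2, joined differently: 3-bromophenyl in place of 4-bromophenyl on a double-bonded chain carbon bound to a double-bonded chain carbon. The change is 3-bromophenyl in place of 4-bromophenyl on a double-bonded chain carbon bound to a double-bonded chain carbon.

Among the compounds with values here, the only measured single-place step is a 2.2-fold higher number from compound 1 to compound 3 (0.33 log units; beyond the scatter), with hydrogen in place of methoxy on an aromatic carbon. That step is modest and concerns a different change. Within the data shown here, no measured step moves a bromine, so the data offer no direct guide and favour no direction. The expectation therefore starts from compound 2 at 243 umol/kg, and no step beyond the scatter is expected in this assay. The estimated change is a 1.1-fold lower number from compound 2 to compound 4 (0.04 log units; within the scatter). For compound 4 the expected value is 220 umol/kg, with an estimated range of 110 umol/kg to 450 umol/kg.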

Compound 4, dose for half-maximal effect: 260 umol/kg
Estimate against measurement, compound 4: 1.2-fold (0.07 log units) below, within the range that was stated.
By their numbers in this assay, from the lowest: compound 1; then compounds 3, 2 and 4 (each within the scatter of the next).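

Moving the bromine, with 3-bromophenyl in place of 4-bromophenyl on a double-bonded chain carbon bound to a double-bonded chain carbon, gives a 1.1-fold higher number from compound 2 to compound 4 (0.03 log units; within the scatter) in this assay, so this pair cannot be told apart in this assay. Unlike the earlier step, this one leaves the atoms unchanged and alters only how they are joined, and the place of the bromine on this phenyl group makes no difference beyond the scatter here. No available evidence bears on this result.

Going by these compounds, only these two bromine places are covered, so the effect of 2-bromophenyl at the same chain carbon remains open. On these data alone, it is also open whether replacing the bromine with an amine or a carboxylic acid would give a step beyond the scatter, and unsubstituted phenyl would show what the bromine itself contributes.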